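A few compounds are considered here, and "the series" means these few. Any claim that something is new, unique, unknown or untested is made for them only; others in the source may bear on it.

The measured compounds:
compound 1 `CCCSc1nc(N/N=C/c2ccc(C)cc2)c2nnn(Cc3ccccc3)c2n1`: > 64000 nM
compound 2 `C#CCSc1nc(N/N=C/c2cc(OC)c(OC)c(OC)c2)c2nnn(Cc3ccccc3)c2n1`: 4670 nM

Both values come from a functional assay on MGC-803 cells (Homo sapiens) for antiproliferative activity, read by MTT assay, with a stated time of 72 h; a lower number here means a stronger inhibitor, a higher number a weaker inhibitor. Compound 1 gives > 64000 nM, which is not a number but a limit of the assay. Compound 2 gives 4670 nM in this assay, a measured number. Compound 1 therefore stands only on a limit, as shown by the limit of > 64000 nM in this assay, at which 1 of the 2 values shown sits, and its true position is known merely as a range, not as a point.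

The compound to be tested next is compound 3 `CCCSc1nc(N/N=C(\C)c2ccc(Br)cc2)c2nnn(Cc3ccccc3)c2n1`. Its structure differs from compound 1 by a group of 10 heavy atoms (8 carbon, 1 nitrogen, 1 bromine; one six-membered aromatic ring of carbon only) in place of a group of 9 heavy atoms (8 carbon, 1 nitrogen; one six-membered aromatic ring of carbon only), on a nitrogen on an aromatic ring.

Within the data shown here, no step between two measured compounds is at hand that resembles this change, so its size cannot be read from the data. Because compound 1 shows only a limit > 64000 nM, any expectation for compound 3 rests on little. Compound 3 is expected to remain a weak inhibitor, with a step of an at least 1.4-fold lower number from compound 1 to compound 3 (0.15 log units; that floor lies within the scatter) that, if it exists, is small and could go either way. The estimate for compound 3 in this assay is 45000 nM, within a range from 12000 nM to 130000 nM.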

Compound 3, half-maximal inhibitory concentration: 6020 nM
Beside the measured number, compound 3's estimate is 7.5-fold (0.87 log units) above it; the whole stated range lies above it.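

Swapping the group on a nitrogen on an aromatic ring turns out to matter a great deal in this assay: the swap gives an at least 10-fold lower number from compound 1 to compound 3 (1.02 log units; beyond the scatter), even though the entering group has only slightly more heavy atoms than the one it replaces. Both groups hold one six-membered aromatic ring of carbon only and one double bond outside aromatic rings, and they have the same count of carbon atoms, but only the entering group carries a bromine and its carbons are arranged differently. The step gives only the smallest possible size of the change, not its full size, because the value of compound 1 is a limit and not a number: the limit of > 64000 nM in this assay, at which 1 of the 3 values shown sits.

Since the bromine and the rearranged carbons arrive together, the compounds shown cannot tell which of the two carries the gain, and compound 2 differs from compound 1 and from compound 3 in more than one place, so it cannot settle this. Also open, on these data alone, is how the activity would respond if a chlorine atom or an amine stood where the bromine stands in compound 3.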